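Biaryl nitrile benzothiazoles tested for glutamate receptor blockade

A few compounds are considered here, and "the series" means these few. Any claim that something is new, unique, unknown or untested is made for them only; others in the source may bear on it.

The series rests on two measured entries. Compound 1 `N#Cc1cc(-c2ccc3scnc3c2)ccc1-c1cccnc1` was tested in an in vitro functional assay on HEK293-A cells for antagonist activity at metabotropic glutamate receptor 5 (Rattus norvegicus), read by fluorescence and calcium flux, with a stated time of 140 s (on this read-out lower numbers stand for stronger inhibition and higher numbers for weaker inhibition), and compound 1 gives > 10000 nM, a limit of the assay rather than a number. Compound 2 `Cc1nc2cc(-c3cccc(C#N)c3)ccc2s1` stands without any figure of its own, since in this assay compound 2 gives "not determined" (no result reported). What surrounds compound 2 is therefore only (the limit of > 10000 nM in this assay, at which 1 of the 2 values shown sits). Compound 3 `Cc1nc2cc(-c3ccc(-c4ccc(F)cc4)c(C#N)c3)ccc2s1` differs from compound 2 by 4-fluorophenyl in place of hydrogen on an aromatic carbon. Among the measured compounds shown here, no measured pair in this set shows what such an addition does, so no direction for the step can be taken from the data. Given that compound 1 sits at the limit of > 10000 nM in this assay, at which 1 of the 2 values shown sits, the expectation for compound 3 in this assay is a weak result near 5000 nM, spanning from 500 nM to 30000 nM, with a real chance that only a limit is reported. The measured figure for compound 3 follows.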

Compound 3, half-maximal inhibitory concentration: > 10000 nM
Compound 3 gave a limit, no number; the forecaster's own chance of this, stated with the estimate: 55%; middle value at least 2.0-fold (0.30 log units) away from the limit.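

In this assay compound 3 gives > 10000 nM, a limit and not a number. As compound 2 carries no figure, no step can be read from compound 2 to compound 3. The compounds shown leave open what the 4-fluorophenyl addition does to inhibition.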